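The compounds below may be only part of what the source reports. "The series", "measured", "known", "first", "only" and "open" are said of these compounds alone.

Compound 1 `CCCCCCCCCCOc1cccc(O)c1C(=O)/C=C/c1ccc(O)cc1`, compound 2 `CCCCCCCCCCOc1cccc(O)c1C(=O)/C=C/c1cccc(O)c1` and compound 3 `CCCCCCCCCCOc1cccc(O)c1C(=O)/C=C/c1ccc(C)cc1` share one core and differ only in the aromatic group on a double-bonded chain carbon. In an ADME assay on RAW264.7 cells (Mus musculus) for cytotoxicity, read by MTT assay (a lower number here means a stronger inhibitor, a higher number a weaker inhibitor), compound 1 gives > 30000 nM, which is a limit and not a number. Compound 2 gives > 30000 nM, again a limit. Compound 3 gives > 30000 nM, also a limit. Compound 3 therefore has no exact place on the scale and stands with the other two: the limit of > 30000 nM in this assay, at which 3 of the 3 values shown sit.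

Compound 4 `CCCCCCCCCCOc1cccc(O)c1C(=O)/C=C/c1ccc(Cl)c(Cl)c1` carries 3,4-dichlorophenyl in place of 4-methylphenyl on a double-bonded chain carbon bound to a double-bonded chain carbon.

Three measured steps change the same group: a step that the two limits leave unreadable from compound 1 to compound 2, a step that the two limits leave unreadable from compound 1 to compound 3 and a step that the two limits leave unreadable from compound 2 to compound 3. None has a readable size, so they show no direction. All they show is that these three compounds end at the same limit. None of them carries chlorine, so compound 4 could still give a real number.

The expected change is a number no higher from compound 3 to compound 4 (the limit leaves the size open), meaning no shift beyond the usual scatter is anticipated in either direction. For compound 4 the estimated value in this assay is 30000 nM, with an expected range from 12000 nM to 60000 nM.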

Compound 4, half-maximal inhibitory concentration: > 30000 nM
Compound 4: only a limit was reported; the forecaster's own chance of this, stated with the estimate: 75%; the middle value lies on the limit itself.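

In this assay compound 4 gives > 30000 nM, again a limit and not a number. The steps to compound 4 from compound 1, compound 2 and compound 3 cannot be read, as each joins two limits. The compounds shown leave open where any of the four would fall on the scale of this assay, and whether swapping the aromatic group changes that value at all.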